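Cytotoxicity notes: pyridyl to phenyl in one series

The source may report more compounds than this note shows. Statements on the series, on what has been measured and on what is new or still open speak of the compounds shown alone.

Measured in an ADME assay on L6 cells (Rattus norvegicus) for cytotoxicity, read by fluorescence and resazurin assay, with a stated time of 72 h; a higher number here means that more compound is needed for the effect, a lower number that less compound is needed:
compound 1 `Cc1cc(-c2ccc3[nH]c(=O)nc(-c4ccccc4)c3c2)ccn1` gives > 50000 nM, a limit of the assay.
compound 2 `Cc1ccncc1-c1ccc2[nH]c(=O)nc(-c3ccccc3)c2c1` gives > 50000 nM, a limit of the assay.
compound 3 `Cc1cncc(-c2ccc3[nH]c(=O)nc(-c4ccccc4)c3c2)c1` gives > 50000 nM, a limit of the assay.

Compound 3 therefore stands only at a limit in this assay, as do the other two. The steps a step that the two limits leave unreadable from compound 1 to compound 2, a step that the two limits leave unreadable from compound 1 to compound 3 and a step that the two limits leave unreadable from compound 2 to compound 3 cannot be read, because of the limit of > 50000 nM in this assay, at which 3 of the 3 values shown sit. Compound 4 `O=c1nc(-c2ccccc2)c2cc(-c3ccccc3)ccc2[nH]1` differs from compound 3 by phenyl in place of 5-methylpyridin-3-yl on an aromatic carbon. The measured steps bear on this change only in that exchanging one methylpyridinyl for another left every value at the limit; none gives a readable size or direction. No step beyond the scatter is expected in this assay. Compound 4 is expected to come out at 60000 nM (range 30000 nM to 200000 nM), most likely again as a limit. The expected step that the limit leaves unreadable from compound 3 to compound 4 is estimated to be small.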

Compound 4, half-maximal effective concentration: > 50000 nM
Compound 4 gave a limit, no number (the forecaster's own chance of this, stated with the estimate: 80%); the middle value is on the limit's open side.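

The steps from compound 1, compound 2 and compound 3 to compound 4 cannot be read, because all four compounds sit at the same limit: the limit of > 50000 nM in this assay, at which 4 of the 4 values shown sit.

From the compounds shown here alone, whether phenyl and the methylpyridinyl groups differ at all in this assay stays open.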